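Replacing nitro with methoxy on compound 3

A few compounds are considered here, and "the series" means these few. Any claim that something is new, unique, unknown or untested is made for them only; others in the source may bear on it.

In a functional assay on MGC-803 cells (Homo sapiens) for antiproliferative activity, read by MTT assay, with a stated time of 48 h (a lower number here means that less compound is needed, a higher number that more compound is needed for the effect), compound 1 `COc1ccc(C(=O)N2N=C(C)CC2c2ccccc2O)cc1` gives 38500 nM, compound 2 `CC1=NN(C(=O)CCl)C(c2cc(F)ccc2O)C1` gives 6870 nM and compound 3 `CC1=NN(S(=O)(=O)c2ccc([N+](=O)[O-])cc2)C(c2cc(Br)ccc2O)C1` gives 22200 nM. Compound 3 lies within the scatter of compound 1, so these two cannot be ranked against each other. Compound 3 does need more compound than compound 2, and that gap lies beyond the scatter.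

The next compound, compound 4 `COc1ccc(S(=O)(=O)N2N=C(C)CC2c2cc(Br)ccc2O)cc1`, keeps the rest of compound 3 but has methoxy in place of nitro on an aromatic carbon, para to a large group (methoxy in place of nitro on an aromatic carbon). Going by the values given here, no two measured compounds differ in one place only, so the data offer no direct measure of this change. Compound 1 also carries a methoxy and gives 38500 nM, which is within the scatter of the value for compound 3, but it differs from compound 3 in other places too, so it is only weak guidance.

In this assay, no step beyond the scatter is expected, and the estimated change is a 1.1-fold lower number from compound 3 to compound 4 (0.05 log units; within the scatter). For compound 4 the expected value is 20000 nM, with an estimated range of 7000 nM to 55000 nM.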

Compound 4, half-maximal effective concentration: 20300 nM
The estimate for compound 4 lay 1.0-fold (0.01 log units) below the measured number, within the range that was stated.
By their numbers in this assay, from the lowest: compound 2; then compounds 4, 3 and 1 (each within the scatter of the next).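

In this assay, methoxy in place of nitro on an aromatic carbon, para to a large group, gives a 1.1-fold lower number from compound 3 to compound 4 (0.04 log units; within the scatter), the only direct measure of a single change among these compounds, since the earlier ones all differed from each other in more than one place. With the rest of compound 3 kept, this exchange alters the counts of heavy atoms and hydrogen-bond acceptors and removes a double bond outside aromatic rings, yet it produces no step beyond the scatter, so these two groups cannot be told apart at this position in this assay. The data offer no measured property that bears on this result.

This single pair leaves open whether the position tolerates other groups as well, such as an amine, a carboxylic acid or a longer chain, or whether removing the substituent to leave a plain hydrogen would matter. Also open, from the compounds shown here alone, is whether the same exchange would read the same way with the other parts of the molecule changed, for example with the carbonyl link of compound 1 in place of the sulfonyl link of compound 4.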